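Adding a chloro group to compound 2

The source may hold more compounds than are shown below. What is called first, only, known or untested is meant among the compounds shown, and "the series" means these compounds.

Compound 1 `O=C(CCCCC1CCSS1)NO`: 10.4%
Compound 2 `O=C(CCCCC(CCSC(=O)c1ccccc1)SC(=O)c1ccccc1)Nc1ccccc1`: "not active" (no number reported)

Both compounds were tested in a functional assay on Bel-7402 cells (Homo sapiens) for inhibition, read by MTT assay, with a stated time of 24 h, tested at 0.1 ug/mL; a lower number here means less inhibition of growth, a higher number more inhibition of growth at the concentration tested. Compound 2 has no number in this test. It is reported only as "not active" (no number reported), so it holds no exact place on the scale, whereas compound 1 gives 10.4%.

The next compound is compound 3 `O=C(CCCCC(CCSC(=O)c1ccccc1)SC(=O)c1ccccc1)Nc1ccc(Cl)cc1`, which carries a single change: chloro in place of hydrogen on an aromatic carbon. The phenyl of compound 2 thus becomes 4-chlorophenyl in compound 3. Everything else in the molecule stays the same.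

Going by the values given here, no measured pair of compounds shows what such a swap does here, so the expectation rests on compound 2 alone. Because compound 2 is reported as "not active" (no number reported), the likeliest outcome is no step beyond the usual scatter, and any small shift could only be upward. Compound 3 may also come back without a number. For compound 3 the estimated value in this assay is 5%, with an expected range from 0% to 18%.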

Compound 3, percent growth inhibition at one concentration: 9.2%
The estimate for compound 3 lay 4.2 percentage points below the measured number; measured number inside the range.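

Going by these compounds alone, with compound 2 reported as "not active" (no number reported) and compound 3 at 9.2% there is no number on both sides, so no step between compound 2 and compound 3 can be read. On these data alone, how far chloro in place of hydrogen on the phenyl moves the result in this assay stays open. No measurement shown here offers an explanation for the result of compound 3.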